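The compounds below may be only part of what the source reports. "The series", "measured", "known", "first", "only" and "open" are said of these compounds alone.

Measured so far:
compound 1 `C#CCNC1CCc2c(SCc3cccc(Br)c3)cccc21` — > 100000 nM
compound 2 `C#CCNC1CCc2c(SCCc3cccc(OC)c3)cccc21` — 3820 nM

In an ADME assay on isolated protein for inhibition of Amine oxidase [flavin-containing] B (Homo sapiens) (a lower number here means a stronger inhibitor, a higher number a weaker inhibitor), compound 1 gives only a limit, > 100000 nM, and no number. Compound 1 thus stands at the weak end of what is shown, sitting at the limit of > 100000 nM in this assay, at which 1 of the 2 values shown sits. Compound 2 is measured in this assay at 3820 nM. Compound 3 `C#CCNC1CCc2c(SCc3cccc(F)c3)cccc21` differs from compound 1 by fluoro in place of bromo on an aromatic carbon. Among the compounds with values here, with no measured step to lean on, the expected change in this assay is small, none beyond the scatter, an at least 1.6-fold lower number from compound 1 to compound 3 (0.22 log units; that floor lies within the scatter). Compound 3 is expected at 60000 nM, within 8000 nM to 300000 nM, with a fair chance that only a limit is reported again.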

Compound 3, half-maximal inhibitory concentration: 11600 nM
Estimate against measurement, compound 3: 5.2-fold (0.71 log units) above; measured number inside the range.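

In this assay, the exchange of 3-bromophenyl for 3-fluorophenyl gives the series its first readable single-place step, an at least 8.6-fold lower number from compound 1 to compound 3 (0.93 log units; beyond the scatter), and it lies beyond the scatter. The substituent at this place on the aromatic ring therefore matters for inhibition, and fluoro brings a measured number where bromo gave none. Compound 1 holds only a limit, so this step is a floor and not a full size: the limit of > 100000 nM in this assay, at which 1 of the 3 values shown sits.

The compounds shown leave open how chloro, a nitrile or plain hydrogen at this place would read. Also open, on these data alone, is whether the fluoro gain persists with a longer chain to the ring.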